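This account rests on a few compounds, and the source may have more. Where it says the series, first, only, none or still open, it means among the compounds named here.

Compounds measured in a functional assay on HeLa cells (Homo sapiens) for antiproliferative activity, read by CCK-8 assay, with a stated time of 72 h, tested at 2 uM; a higher number here means a stronger effect of the compound at the concentration tested, a lower number a weaker effect:

Compound 1, `Nc1ccccc1NC(=O)c1ccc(CSC(=S)N2CCN(C(c3ccccc3)c3ccccc3)CC2)cc1` — 8%
Compound 2, `Nc1ccccc1NC(=O)c1ccc(CSC(=S)N2CCN(Cc3ccccc3)CC2)cc1` — 20.6%
Compound 3, `COC(=O)c1ccc2c(c1)CCN2C(=S)SCc1ccc(C(=O)Nc2ccccc2N)cc1` — 45.3%

Compound 2 holds the second highest of the three numbers in this assay. Its nearest neighbour is compound 1, which gives 8%, and the step of a number 12.6 percentage points higher from compound 1 to compound 2 (beyond the scatter) separates the two. Compound 3, built on a different core, stands furthest away with 45.3%, well above compound 2.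

Compound 4, `Nc1ccccc1NC(=O)c1ccc(CSC(=S)N2CCN(c3ccccc3)CC2)cc1`, has not yet been measured in this assay. It differs from compound 2 in one place: phenyl in place of benzyl on an amine nitrogen in a ring. For the measured compounds named here, the only measured step that touches the same region of the molecule is a number 12.6 percentage points higher from compound 1 to compound 2 (beyond the scatter), where a hydrogen replaced a phenyl on the saturated chain carbon bound to the ring nitrogen. Going by the values given here, the present change instead removes that chain carbon altogether and joins the phenyl directly to the amine nitrogen in the ring, which no measured pair covers. Among the compounds with values here, the account therefore has no step that bears directly on the change, and a step within the scatter, in either direction, is expected for a number 3.4 percentage points higher from compound 2 to compound 4 (within the scatter). Compound 4 is estimated at 24%, with a range from 8% to 42%.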

Compound 4, a percentage reported as inhibition, at one concentration (the size of the read-out at that concentration, not a potency): 62.2%
Compound 4: the middle estimate sits 38.2 percentage points below what was measured; the whole stated range lies below it.
By their numbers in this assay, from the lowest: compound 1; then compound 2; then compound 3; then compound 4.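

In this assay, for the compounds shown here, the position on the amine nitrogen in the ring proves far more sensitive than the earlier compounds suggested: taking out the chain carbon of benzyl, so that phenyl stands directly on that nitrogen, gives a number 41.6 percentage points higher from compound 2 to compound 4 (beyond the scatter), a large step from a change of a single heavy atom. The earlier step, a number 12.6 percentage points higher from compound 1 to compound 2 (beyond the scatter), showed only that removing a phenyl from that chain carbon raises the number modestly, and across these two steps the number rises each time the group on this nitrogen is cut back. Benzyl and phenyl have the same counts of aromatic rings, hydrogen-bond donors and acceptors and neither carries a net charge, and nothing available here explains the size of the step.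

The compounds shown leave open whether a longer chain such as phenethyl, a pyridine ring in place of phenyl, or a phenyl carrying a fluorine or methoxy group would follow the same trend. They also leave open whether the step holds as a difference in potency, since each number is a read-out at a single concentration.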